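The source may hold more compounds than are shown below. What is called first, only, known or untested is meant among the compounds shown, and "the series" means these compounds.

Working notes on the series. In an assay on isolated protein for inhibition of Amine oxidase [flavin-containing] B (Homo sapiens), read by spectrophotometry (a lower number here means a stronger inhibitor, a higher number a weaker inhibitor), compound 1 `COc1ccc(/C(C)=N/Nc2nc3ccccc3nc2Cc2ccccc2)cc1` gives 280000 nM; compound 2 `C/C(=N\Nc1nc2ccccc2nc1Cc1ccccc1)c1ccccc1` gives 980000 nM in this assay, and compound 3 `Oc1ccc(/C=N/Nc2nc3ccccc3nc2Cc2ccccc2)cc1` gives 7900000 nM, the highest number of the three. The two measured steps are a 3.5-fold higher number from compound 1 to compound 2 (0.54 log units; beyond the scatter) and an 8.1-fold higher number from compound 2 to compound 3 (0.91 log units; beyond the scatter). Compound 4 `C/C(=N\Nc1nc2ccccc2nc1Cc1ccccc1)c1ccccn1` differs from compound 3 by a group of 9 heavy atoms (7 carbon, 2 nitrogen; one six-membered aromatic ring with 1 hetero atom) in place of a group of 9 heavy atoms (7 carbon, 1 nitrogen, 1 oxygen; one six-membered aromatic ring of carbon only), on a nitrogen on an aromatic ring. This change largely undoes the one seen in an 8.1-fold higher number from compound 2 to compound 3 (0.91 log units; beyond the scatter), and compound 4 matches compound 2 apart from the ring with one hetero atom, so that step bears directly while a 3.5-fold higher number from compound 1 to compound 2 (0.54 log units; beyond the scatter) bears only in passing. The number for compound 4 is therefore expected to fall back toward that of compound 2, an expected step of a 6.6-fold lower number from compound 3 to compound 4 (0.82 log units; beyond the scatter). The estimate for compound 4 is 1200000 nM, with a range of 300000 nM to 5000000 nM.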

Compound 4, half-maximal inhibitory concentration: 980000 nM
For compound 4 the middle estimate is 1.2-fold (0.09 log units) above the measured one, within the range that was stated.
By their numbers in this assay, from the lowest: compound 1; then compounds 2 and 4 (each within the scatter of the next); then compound 3.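

On the carbon with a double bond to nitrogen, pyridin-2-yl in place of phenyl gives (no change at the digits printed from compound 2 to compound 4 (within the scatter)) in this assay, so a ring nitrogen at this position stands within the scatter of the all-carbon ring. The same group gives a 3.5-fold higher number from compound 1 to compound 4 (0.54 log units; beyond the scatter) against 4-methoxyphenyl, and the larger exchange gives an 8.1-fold lower number from compound 3 to compound 4 (0.91 log units; beyond the scatter). No evidence bears on the reason for these results. The exchange between compound 3 and compound 4 alters both the ring and the group on that carbon, leaving their separate contributions open. Also open, going by these compounds, are pyridin-3-yl, pyridin-4-yl and an amine on this ring.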